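The source may report more compounds than this note shows. Statements on the series, on what has been measured and on what is new or still open speak of the compounds shown alone.

Measured so far in a physicochemical assay for lipophilicity; a lower number here means a more polar compound, a higher number a more lipophilic compound:
- compound 1 `COc1ccccc1C1=NC(c2ccccc2)CO1`: 3.76
- compound 2 `Fc1cccc(Cl)c1-c1ncco1`: 1.89

Of these two, compound 2 stands lower at 1.89, and its gap to compound 1 lies beyond the scatter. Among the measured compounds shown here, the two compounds differ in more than one place, so no single-change step is available as a guide.

Compound 3 `Fc1cccc(F)c1-c1ncco1` has not yet been measured in this assay. It carries fluoro in place of chloro on an aromatic carbon.

For the measured compounds named here, with only this structural change to go on, a downward move of moderate size is expected, probably just beyond the scatter. The expected step is a number 0.44 log units lower from compound 2 to compound 3 (beyond the scatter). The estimate for compound 3 is 1.45, with an expected range of 1.1 to 1.8.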

Compound 3, partition coefficient: 1.45
For compound 3 middle estimate and measured number coincide at the digits printed; low and high end bracket the measured number.
By their numbers in this assay, from the lowest: compound 3; then compound 2; then compound 1.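

In this assay the change of chloro to fluoro on an aromatic carbon, ortho to a group of 5 heavy atoms and meta to a fluoro group, gives a number 0.44 log units lower from compound 2 to compound 3 (beyond the scatter) as a modest step. Among the compounds shown here, this is the first single-change reading, and it gives this position a direction and a size that the comparison of compound 1 and compound 2, which differ in more than one place, could not give. The leaving and entering groups each count 1 heavy atom with no hydrogen-bond donors or acceptors and no net charge, and no measurement at hand bears on the origin of the step.

As far as these compounds go, whether a step of this size carries over to another core, such as the core of compound 1, stays open. So does the reading at this position with a group beyond the two halogens shown, such as an amine or a carboxylic acid.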